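Cytotoxicity series: substituent exchange on the anilide ring

This account rests on a few compounds, and the source may have more. Where it says the series, first, only, none or still open, it means among the compounds named here.

Compound 1 `CC(C)(C)OC(=O)c1cccc(NC(=O)C2CCCN(C(=O)c3cc(C(F)(F)F)cc(C(F)(F)F)c3)C2)c1` gives 0% in an ADME assay on PC-3 cells (Homo sapiens) for cytotoxicity, read by WST assay, tested at 100 uM; a higher number here means more inhibition at the concentration tested (going by the name of the read-out), a lower number less inhibition. Compound 2 `O=C(Nc1cccc(OCCc2ccccn2)c1)C1CCCN(C(=O)c2cc(C(F)(F)F)cc(C(F)(F)F)c2)C1` gives 5% in this assay, and compound 3 `O=C(c1ccccc1)c1cccc(NC(=O)C2CCCN(C(=O)c3cc(C(F)(F)F)cc(C(F)(F)F)c3)C2)c1` gives 0% in this assay. Compound 3 stands level with compound 1, the two together the lowest of the three numbers; its nearest neighbour is compound 1, with no change at the digits printed from compound 1 to compound 3 (within the scatter), and its furthest is compound 2, with a number 5 percentage points lower from compound 2 to compound 3 (within the scatter). The remaining single step in the series is a number 5 percentage points higher from compound 1 to compound 2 (within the scatter). None of the three steps leaves the scatter.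

Compound 4 `C=CCOc1cccc(NC(=O)C2CCCN(C(=O)c3cc(C(F)(F)F)cc(C(F)(F)F)c3)C2)c1` differs from compound 3 by allyloxy in place of benzoyl on an aromatic carbon. The exchange leaves a benzoyl and enters an allyloxy on an aromatic carbon of a six-membered aromatic ring of carbon only, meta to a large group. The measured steps that bear on it are the two earlier exchanges at this aromatic carbon, tert-butoxycarbonyl to 2-(pyridin-2-yl)ethoxy (a number 5 percentage points higher from compound 1 to compound 2 (within the scatter)) and 2-(pyridin-2-yl)ethoxy to benzoyl (a number 5 percentage points lower from compound 2 to compound 3 (within the scatter)), both within the scatter. No exchange at this position has moved this assay beyond the scatter, so for compound 4 no step beyond the scatter is expected, a number 2 percentage points higher from compound 3 to compound 4 (within the scatter). Compound 4 is estimated at 2%, in the range -8% to 12%.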

Compound 4, a percentage reported as inhibition, at one concentration (the size of the read-out at that concentration, not a potency): 0%
For compound 4 the middle estimate is 2 percentage points above the measured one; measured number inside the range.
By their numbers in this assay, from the lowest: compounds 1, 3, 4 and 2 (each within the scatter of the next).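

At this aromatic carbon the series now holds an entering group with no ring: allyloxy, with 4 heavy atoms against the 8 of benzoyl, gives no change at the digits printed from compound 3 to compound 4 (within the scatter) in this assay, so losing the six-membered aromatic ring of benzoyl does not take the number out of the scatter. Against the other two groups the picture is the same, with no change at the digits printed from compound 1 to compound 4 (within the scatter) for allyloxy in place of tert-butoxycarbonyl and a number 5 percentage points lower from compound 2 to compound 4 (within the scatter) for vinyl in place of (pyridin-2-yl)methyl on the saturated chain carbon, which leaves tert-butoxycarbonyl, 2-(pyridin-2-yl)ethoxy, benzoyl and allyloxy all within the scatter of one another across these four compounds. Nothing at hand offers an explanation for how closely these numbers sit together.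

The compounds shown leave open whether any group at this aromatic carbon can move this assay beyond the scatter, for instance a primary amine, a carboxylic acid or a longer alkoxy chain. They also leave open whether an exchange elsewhere on the shared core, such as chlorine in place of a trifluoromethyl group, would do so.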